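Methoxy on a second position of the fused core

This account rests on a few compounds, and the source may have more. Where it says the series, first, only, none or still open, it means among the compounds named here.

Compound 1 `O=C(NC1CCN(Cc2ccccc2)CC1)c1coc2ccccc2c1=O` stands highest of the two numbers in an assay on isolated protein for inhibition of Amine oxidase [flavin-containing] A (Homo sapiens), read by fluorescence and Amplex Red, with stated times of 15 min and 20 min, tested at 100 uM (on this read-out lower numbers stand for less inhibition and higher numbers for more inhibition at the one concentration tested (going by the name of the read-out)), giving 63.8%. Compound 2 `COc1ccc2occ(C(=O)NC3CCN(Cc4ccccc4)CC3)c(=O)c2c1`, carrying a methoxy group on the core, gives 7.5% in this assay, and the step from compound 1 is large: a number 56.3 percentage points lower from compound 1 to compound 2 (beyond the scatter). Compound 3 `COc1ccc2c(=O)c(C(=O)NC3CCN(Cc4ccccc4)CC3)coc2c1` differs from compound 1 by methoxy in place of hydrogen on an aromatic carbon, the methoxy now sitting on a different aromatic carbon of the same fused system. For the measured compounds named here, only that one measured step bears on the change, and it was downward and beyond the scatter, so a sizeable drop is expected here too, though the position differs. Compound 3 is estimated at 25%, range 5% to 60%, an expected step of a number 38.8 percentage points lower from compound 1 to compound 3 (beyond the scatter).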

Compound 3, a percentage reported as inhibition, at one concentration (the size of the read-out at that concentration, not a potency): 37.4%
Compound 3: middle estimate off by 12.4 percentage points, on the low side, and the stated range covers the measured number.
By their numbers in this assay, from the lowest: compound 2; then compound 3; then compound 1.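

Methoxy on this aromatic carbon also lowers the number in this assay (a number 26.4 percentage points lower from compound 1 to compound 3 (beyond the scatter)), so the loss is not confined to the single carbon substituted in compound 2. The two placements do not read alike: compound 2 gives 7.5% and compound 3 gives 37.4% at the same concentration. No measurement here bears on why methoxy lowers the number at either carbon. Open, on these data alone, is whether fluorine or hydroxy on this carbon would follow methoxy, and how methoxy reads on the remaining aromatic carbons of the shared core.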